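Swapping methoxy for fluoro on a phenylpiperazine nitroimidazole

The source may report more compounds than this note shows. Statements on the series, on what has been measured and on what is new or still open speak of the compounds shown alone.

Compound 1: `Cc1ncc([N+](=O)[O-])n1CC(O)CSC(=S)N1CCN(c2cccc(Cl)c2)CC1` — 1080000 nM
Compound 2: `Cc1ncc([N+](=O)[O-])n1CC(O)CSC(=S)N1CCCC(C)C1` — 609000 nM
Compound 3: `COc1ccccc1N1CCN(CC(O)Cn2c([N+](=O)[O-])cnc2C)CC1` — 4390000 nM

Of the compounds shown here, three sharing a nitroimidazole core have been tested in a toxicity assay on HeLa cells (Homo sapiens) for cytotoxicity, read by MTT assay, with a stated time of 24 h; on this read-out lower numbers stand for stronger inhibition and higher numbers for weaker inhibition. Compound 1 gives 1080000 nM in this assay, and compound 2 gives 609000 nM. Compound 3 gives 4390000 nM, the highest of the three numbers, and so the weakest cytotoxicity seen here: its value lies beyond the scatter above both compound 1 and compound 2. Among the measured compounds shown here, compound 2 carries a dithiocarbamate and a methylpiperidine where compound 3 carries a methoxyphenyl piperazine joined directly to the hydroxypropyl chain, so these pairs differ in more than one place and no single step between them can be read.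

Compound 4, `Cc1ncc([N+](=O)[O-])n1CC(O)CN1CCN(c2ccccc2F)CC1`, has not yet been measured. It is the closest relative of compound 3: the change is fluoro in place of methoxy on an aromatic carbon, ortho to the large piperazine group. Such a small change at the edge of the molecule, with no precedent among the measured compounds, is not expected to move the number beyond the scatter in either direction. The estimate for compound 4 in this assay is therefore 3500000 nM, with a range from 1200000 nM to 10000000 nM, which corresponds to an expected step of a 1.3-fold lower number from compound 3 to compound 4 (0.10 log units; within the scatter).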

Compound 4, half-maximal inhibitory concentration: > 5000000 nM
Compound 4 ended at the assay's limit; the forecaster's own chance of this, stated with the estimate: 20%; at least 1.4-fold (0.15 log units) between middle value and limit.
By their numbers in this assay, from the lowest: compounds 2 and 1 (each within the scatter of the next); then compound 3. At a limit, above all of these: compound 4.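

In this assay compound 4 gives > 5000000 nM, which is a limit of the assay and not a number. Fluoro in place of methoxy on an aromatic carbon, ortho to a large group, is the first change in one place that can be followed in this set, and it gives an at least 1.1-fold higher number from compound 3 to compound 4 (0.05 log units; that floor lies within the scatter). This swap therefore shows no sign of stronger cytotoxicity at this position, but how far the true number lies past that of compound 3 cannot be told because the reading stopped at the limit of the assay: the limit of > 5000000 nM in this assay, at which 1 of the 4 values shown sits.

The compounds shown leave open what an amine or a carboxylic acid on this same aromatic carbon would do, and whether a longer chain in place of the methoxy would bring the number down into the range that can be measured. From the compounds shown here alone, the pairs that join compound 1 or compound 2 to compound 3 or compound 4 differ in more than one place and their steps cannot be read, so the part played by the remaining differences in the chain and the ring system stays untested here.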